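Replacing a carbamate with an oxadiazole on the piperazine nitrogen

The compounds below may be only part of what the source reports. "The series", "measured", "known", "first", "only" and "open" are said of these compounds alone.

Two measured compounds set the scene. Compound 1 `C[C@@H]1CN(C(=O)OC(C)(C)C)CCN1c1ncc(OCc2ccc(S(=O)(=O)N(C)C)cc2)cn1` in an in vitro functional assay on HEK293S cells for agonist activity at Glucose-dependent insulinotropic receptor (Homo sapiens), read by HTRF and cAMP accumulation, with a stated time of 45 min (a higher number here means that more compound is needed for the effect, a lower number that less compound is needed), gives 79 nM. Compound 2 `CC(C)OC(=O)N1CCN(c2ncc(OCc3ccncc3C#N)cn2)[C@H](C)C1` in this assay gives 112 nM, the higher of the two numbers, though the gap to compound 1 lies within the usual scatter, so the two values are read as equivalent. Among the measured compounds shown here, the two differ at more than one place, and no single step connects them.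

Compound 3 `C[C@@H]1CN(c2nc(C3CC3)no2)CCN1c1ncc(OCc2ccncc2C#N)cn1` differs from compound 2 in one place: 3-cyclopropyl-1,2,4-oxadiazol-5-yl in place of isopropoxycarbonyl on an amine nitrogen in a ring. For the measured compounds named here, no measured pair shows what such an exchange does in this assay, so the direction is open. The author expects no step beyond the scatter, with a modest move either way possible, and the step from compound 2 to compound 3 is estimated at a 1.3-fold lower number from compound 2 to compound 3 (0.12 log units; within the scatter). Compound 3 is therefore expected to give about 85 nM in this assay, with a likely range from 25 nM to 300 nM.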

Compound 3, half-maximal effective concentration: 25 nM
For compound 3 the middle estimate is 3.4-fold (0.53 log units) above the measured one, and the stated range covers the measured number.
By their numbers in this assay, from the lowest: compound 3; then compounds 1 and 2 (each within the scatter of the next).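

In this assay, putting 3-cyclopropyl-1,2,4-oxadiazol-5-yl in place of isopropoxycarbonyl on the amine nitrogen in a ring gives a 4.5-fold lower number from compound 2 to compound 3 (0.65 log units; beyond the scatter), a step beyond the scatter. Compounds 1 and 2 both carry a carbamate at this position, so only compound 3 shows that the carbamate can give way to a larger group with an aromatic five-membered ring and a three-membered ring, without a higher number resulting. No independent measurement here bears on why the number falls.

On these data alone, this is a single pair, so it remains open whether the same exchange would give a similar step on the side chain of compound 1. Also open, as far as these compounds go, is how an ethyl or trifluoromethyl group in place of the cyclopropyl, or a urea in place of the oxadiazole, would read at this position.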